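Pyrimidine for oxetane on the ring nitrogen of compound 1

The compounds below may be only part of what the source reports. "The series", "measured", "known", "first", "only" and "open" are said of these compounds alone.

Compound 1 `CN(C[C@H]1Cc2c(cccc2N2CCN(C3COC3)CC2)CN1)[C@H]1CCCc2cccnc21` stands highest of the two numbers measured in an ADME assay on microsomes from liver (Homo sapiens) for metabolic stability, read by LC-MS, with a stated time of 10 min (on this read-out lower numbers stand for a less stable compound and higher numbers for a more stable compound), where compound 1 gives 83.1%. Its nearest neighbour is compound 2 `C[C@@H]1CN(c2cccc3c2C[C@H](CN(C)[C@H]2CCCc4cccnc42)NC3)C[C@H](C)N1C`, which in this assay gives 24.6%; the change between them is a number 58.5 percentage points lower from compound 1 to compound 2 (beyond the scatter). Compound 3 `CN(C[C@H]1Cc2c(cccc2N2CCN(c3ncccn3)CC2)CN1)[C@H]1CCCc2cccnc21` carries a different change at the same region of the shared core: pyrimidin-2-yl in place of oxetan-3-yl on an amine nitrogen in a ring. Among the compounds with values here, only the step from compound 1 to compound 2 bears on this, and it was large, but it alters a different place than the step to compound 3 and so offers a loose guide at best. On that basis the expected step is estimated as a number 25.1 percentage points lower from compound 1 to compound 3 (beyond the scatter), a downward step carrying wide uncertainty. For compound 3 the estimate in this assay is therefore 58%, within a range from 25% to 88%.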

Compound 3, percent of the compound remaining: 35.5%
Compound 3: the middle estimate sits 22.5 percentage points above what was measured, within the range that was stated.
By their numbers in this assay, from the lowest: compound 2; then compound 3; then compound 1.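

In this assay, putting pyrimidin-2-yl in place of oxetan-3-yl on an amine nitrogen in a ring gives a number 47.6 percentage points lower from compound 1 to compound 3 (beyond the scatter). The earlier step, a number 58.5 percentage points lower from compound 1 to compound 2 (beyond the scatter), replaced the whole 4-(oxetan-3-yl)piperazin-1-yl group, whereas this one leaves the ring that bears the nitrogen unchanged and swaps only the group on that nitrogen, which shows that this single change is enough for a large fall in the percent remaining. With both changes falling beyond the scatter, compound 1, the one carrying oxetan-3-yl, holds the highest number of the three.

No measurement at hand accounts for the fall. From the compounds shown here alone, it remains open whether an acetyl group or a tetrahydropyran-4-yl ring on the same nitrogen would keep the number close to that of compound 1.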